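A few compounds are considered here, and "the series" means these few. Any claim that something is new, unique, unknown or untested is made for them only; others in the source may bear on it.

Compound 1 `CN1CCN(c2ccc(Nc3ncc4c(n3)N(C3CCCC3)CC(=O)N4)nc2)CC1` and compound 2 `O=C1CN(C2CCCC2)c2nc(Nc3ccc(N4CCCCC4)cn3)ncc2N1` share a core and differ in one place: piperidin-1-yl in place of 4-methylpiperazin-1-yl on an aromatic carbon. In a functional assay on HCT-116 cells (Homo sapiens) for inhibition, read by MTT assay, with a stated time of 48 h (a higher number here means a weaker inhibitor, a lower number a stronger inhibitor), compound 1 gives only a limit, > 30000 nM. Compound 2 also gives only a limit in this assay, > 30000 nM. So this change yields a step that the two limits leave unreadable from compound 1 to compound 2, because of the limit of > 30000 nM in this assay, at which 2 of the 3 values shown sit.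

Compound 3 `CN1CCN(c2ccc(Nc3ncc4c(n3)N(C3CCCC3)CC(=O)N4C)cc2)CC1` gives 3290 nM in this assay; how its core differs from the core of compound 1 is not broken down here. Compound 4 `CN1C(=O)CN(C2CCCC2)c2nc(Nc3ccc(N4CCCCC4)cc3)ncc21` differs from compound 3 in one place: piperidin-1-yl in place of 4-methylpiperazin-1-yl on an aromatic carbon. This is the same kind of change as from compound 1 to compound 2, not the same: there the group sits on a six-membered aromatic ring with one nitrogen, two atoms from the ring nitrogen, whereas here it sits on a six-membered aromatic ring of carbon only. Since the earlier step could not be read, the step from compound 3 to compound 4 is expected to be a 1.8-fold higher number from compound 3 to compound 4 (0.26 log units; within the scatter), with little support. Compound 4 is estimated at 6000 nM in this assay, between 1500 nM and 30000 nM.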

Compound 4, half-maximal inhibitory concentration: 6100 nM
Compound 4: middle estimate off by 1.0-fold (0.01 log units), on the low side; the measured number falls inside the stated range.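

On the ring of carbon only, piperidin-1-yl in place of 4-methylpiperazin-1-yl gives a 1.9-fold higher number from compound 3 to compound 4 (0.27 log units; within the scatter) in this assay, so on this core the two groups cannot be told apart. Within the data shown here, the same change on the other core, from compound 1 to compound 2, cannot be read, because both compounds give only a limit: the limit of > 30000 nM in this assay, at which 2 of the 4 values shown sit. So there is no pair of readable steps to compare, and this single step does not show whether the change carries the same way from one core to another.

The compounds shown leave open how a different group in the same place, such as morpholin-4-yl or a simple primary amine, would behave in this assay. Among these compounds, they also leave open what separates the two cores, since no single-place step links them.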